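This account rests on a few compounds, and the source may have more. Where it says the series, first, only, none or still open, it means among the compounds named here.

Measured so far: compound 1 `CCSC[C@@](O)([C@@H](Nc1cccc2nc(C)ccc12)c1cccc(F)c1OC)C(F)(F)F` with 69% in a functional assay on THP-1 cells (Homo sapiens) (a lower number here means a smaller maximal response, a higher number a larger maximal response), and compound 2 `CCSC[C@@](O)([C@@H](Nc1cccc2nc(C)ccc12)c1ccc(OC)cc1F)C(F)(F)F` with 85%.

Compound 2 stands highest of the two numbers; its nearest neighbour is compound 1, and the step of a number 16 percentage points higher from compound 1 to compound 2 (beyond the scatter) lies beyond the scatter. Compound 3 `CCSC[C@@](O)([C@@H](Nc1cccc2nc(C)ccc12)c1ccc(Cl)c(F)c1O)C(F)(F)F` differs from compound 2 by 4-chloro-3-fluoro-2-hydroxyphenyl in place of 2-fluoro-4-methoxyphenyl on a saturated chain carbon bound to a nitrogen on an aromatic ring and a saturated chain carbon. Among the compounds with values here, only that one measured step touches the same position, and it shows a modest change from one substituted phenyl to another. Because of a number 16 percentage points higher from compound 1 to compound 2 (beyond the scatter), a step of similar size in either direction is expected, and the account estimates for compound 3 a value of 75%, between 55% and 95%, a step of a number 10 percentage points lower from compound 2 to compound 3 (within the scatter).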

Compound 3, largest response reached (Emax), in percent of the reference or control that the assay uses: 107%
Compound 3: middle estimate off by 32 percentage points, on the low side, outside the stated range (above it).
By their numbers in this assay, from the lowest: compound 1; then compound 2; then compound 3.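

In this assay, the place on a saturated chain carbon bound to a nitrogen on an aromatic ring and a saturated chain carbon can carry the response further than either methoxy-bearing phenyl did: 4-chloro-3-fluoro-2-hydroxyphenyl brings a number 22 percentage points higher from compound 2 to compound 3 (beyond the scatter) and a number 38 percentage points higher from compound 1 to compound 3 (beyond the scatter). The earlier step only moved between two fluoro-methoxyphenyl groups, whereas this change also brings in a hydroxy group and a chlorine. Nothing measured here accounts for the rise.

Going by these compounds, whether the hydroxy group or the chlorine carries the rise stays open, as does how a phenyl bearing an amine or a nitrile would behave at this place.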